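This account rests on a few compounds, and the source may have more. Where it says the series, first, only, none or still open, it means among the compounds named here.

Measured so far: compound 1 `Cc1ccccc1C#Cc1ccc2c(n1)CCN(C)C2=O` with 776 nM in a functional assay on HEK293 cells for negative allosteric modulation of metabotropic glutamate receptor 5 (Homo sapiens), read by FLIPR and calcium flux; on this read-out lower numbers stand for stronger inhibition and higher numbers for weaker inhibition; compound 2 `CN1CCc2nc(C#Cc3ccc(Cl)cc3)ccc2C1=O` with 352 nM.

Compound 1 gives the highest of the two numbers in this assay; the nearest point is compound 2, reached by a 2.2-fold lower number from compound 1 to compound 2 (0.34 log units; beyond the scatter), where a 4-chlorophenyl replaced the 2-methylphenyl on the triple-bonded carbon.

Compound 3 `CN1CCc2nc(C#Cc3cccnc3)ccc2C1=O` is not yet measured. It differs from compound 1 by pyridin-3-yl in place of 2-methylphenyl on a triple-bonded carbon. Among the measured compounds shown here, the only step on the same position is the one from compound 1 to compound 2, which was modest. That step swapped one carbon-only ring for another, whereas here a ring nitrogen enters and the methyl leaves, so it bears on the question only loosely: it shows that this position tolerates change without a large swing in either direction. For the measured compounds named here, no measured step tracks a pyridin-3-yl here. The expectation is therefore a small step, more likely towards a higher number than a lower one, estimated as a 1.8-fold higher number from compound 1 to compound 3 (0.26 log units; within the scatter). Compound 3 is expected to give about 1400 nM in this assay, within the range 450 nM to 4500 nM.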

Compound 3, half-maximal inhibitory concentration: "not active" (no number reported)
The entry for compound 3 holds no number, so the estimate cannot be set against anything.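

In this assay, among the compounds shown here, compound 3 is reported as "not active" with no number, so no step from compound 1 to compound 3 can be read. The compounds shown leave open how far compound 3 lies from compound 1 on this read-out. Nothing shown gives an explanation for this result.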